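Hexyl on the bare core: tolerated-concentration outlook

The compounds below may be only part of what the source reports. "The series", "measured", "known", "first", "only" and "open" are said of these compounds alone.

The series shares the core seen in compound 3 `O=c1nc2occc2cn1COCCO`, the unsubstituted parent. In a functional assay on HEL cells (Homo sapiens), read by microscopy (a higher number here means that more compound is tolerated, a lower number that less compound is tolerated), compound 3 reaches only an assay limit, > 400000 nM (the limit of > 400000 nM in this assay, at which 1 of the 3 values shown sits). Two longer-chain analogues are known. Compound 1 `CCCCCCCC#Cc1cc2cn(COCCO)c(=O)nc2o1` carries an octynyl chain, and in this assay compound 1 gives 200000 nM. Compound 2 `CCCCCCCCCc1cc2cn(COCCO)c(=O)nc2o1` carries a nonyl chain; in this assay compound 2 also sits at a limit, >= 16000 nM (the limit of >= 16000 nM in this assay, at which 1 of the 3 values shown sits). Among the measured compounds shown here, no single-point step between the measured compounds is available, so only the values themselves can be compared: compound 1 lies well under the limit reported for compound 3, while the limit for compound 2 leaves its distance from both open.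

Compound 4 `CCCCCCc1cc2cn(COCCO)c(=O)nc2o1` is the next candidate: hexyl in place of hydrogen on an aromatic carbon. Hexyl in place of hydrogen on an aromatic carbon is expected to lower the value in this assay beyond the usual scatter, toward less tolerated compound, because compound 1 gives 200000 nM with a chain of related kind. For compound 4 the expected value is 100000 nM, within 25000 nM to 400000 nM. The estimated step is an at least 4.0-fold lower number from compound 3 to compound 4 (0.60 log units; beyond the scatter).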

Compound 4, minimum cytotoxic concentration: >= 400000 nM
Compound 4: no number, only a limit (the forecaster's own chance of this, stated with the estimate: 35%); at least 4.0-fold (0.60 log units) between middle value and limit.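

Compound 4 reaches only a limit in this assay, >= 400000 nM. Among the compounds shown here, compound 2 and compound 3 also stand at limits, so no step to compound 4 can be read from either. From the compounds shown here alone, whether hexyl in place of hydrogen on an aromatic carbon changes the tolerated concentration remains open.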